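Adding one fluoro to a compound at the limit

The source may report more compounds than this note shows. Statements on the series, on what has been measured and on what is new or still open speak of the compounds shown alone.

Measured in a functional assay on HepG2 cells (Homo sapiens) for cytotoxicity, with a stated time of 72 h; a lower number here means that less compound is needed, a higher number that more compound is needed for the effect:
- compound 1 `C=C[C@@](C)(/C=C/c1ccc(OC)cc1)CCC=C(C)C`: > 52000 nM
- compound 2 `C=C[C@@](C)(/C=C/c1ccc(OCc2ccccc2)cc1)CCC=C(C)C`: > 52000 nM
- compound 3 `C=C[C@@](C)(/C=C/c1ccc(Nc2ccc(OC)cc2)cc1)CCC=C(C)C`: > 52000 nM

Each of these values is a limit, not a number. Compound 3 stands at > 52000 nM, which is a limit. Compound 4 `C=C[C@@](C)(/C=C/c1ccc(Nc2ccc(OC)c(F)c2)cc1)CCC=C(C)C` differs from it by fluoro in place of hydrogen on an aromatic carbon, ortho to a methoxy group. Among the measured compounds shown here, three measured steps bear on this only loosely: a step that the two limits leave unreadable from compound 1 to compound 2, a step that the two limits leave unreadable from compound 1 to compound 3 and a step that the two limits leave unreadable from compound 2 to compound 3. None of them gives a size, and all three compounds share (the limit of > 52000 nM in this assay, at which 3 of the 3 values shown sit). No step beyond the scatter is therefore expected in this assay, and no direction can be named. The expected change is a step that the limit leaves unreadable from compound 3 to compound 4. Compound 4 is expected at 55000 nM, with an estimated range of 30000 nM to 100000 nM.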

Compound 4, half-maximal effective concentration: > 52000 nM
Compound 4 gave a limit, no number; the forecaster's own chance of this, stated with the estimate: 85%; the middle value lies beyond the limit too.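

Among the compounds shown here, compound 3 and compound 4 both end at a limit rather than a number, so no step for the added fluoro can be read in this assay: the limit of > 52000 nM in this assay, at which 4 of the 4 values shown sit. The compounds shown leave open whether fluoro changes this effect at all, and which change to the shared core would give a readable number.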